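Swapping the benzoxazole for a bromodihydroindole thiocarbamate

A few compounds are considered here, and "the series" means these few. Any claim that something is new, unique, unknown or untested is made for them only; others in the source may bear on it.

The three compounds measured share one core, an amide bearing a trimethoxyphenyl group and a methoxybenzyl group, and differ only in what hangs from the sulfur. Compound 1 `COc1ccc(CN(C(=O)CSc2nc3ccccc3o2)c2cc(OC)c(OC)c(OC)c2)cc1` gives 3280 nM in a functional assay on HCT-116 cells (Homo sapiens) for inhibition, read by CCK-8 assay, with a stated time of 48 h (on this read-out higher numbers stand for weaker inhibition and lower numbers for stronger inhibition), the lowest of the three numbers and so the strongest inhibitor here. Compound 2 `CCN1CCN(C(=S)SCC(=O)N(Cc2ccc(OC)cc2)c2cc(OC)c(OC)c(OC)c2)CC1` gives 7700 nM, a step of a 2.3-fold higher number from compound 1 to compound 2 (0.37 log units; beyond the scatter). Compound 3 `COc1ccc(CN(C(=O)CSC(=S)N2CCc3ccccc32)c2cc(OC)c(OC)c(OC)c2)cc1` gives 7710 nM, a step of a 2.4-fold higher number from compound 1 to compound 3 (0.37 log units; beyond the scatter); between compound 2 and compound 3 the step is a 1.0-fold higher number from compound 2 to compound 3 (0.00 log units; within the scatter).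

Compound 4 `COc1ccc(CN(C(=O)CSC(=S)N2CCc3cc(Br)ccc32)c2cc(OC)c(OC)c(OC)c2)cc1` has not yet been measured. It differs from compound 1 in this way: a group of 12 heavy atoms (9 carbon, 1 nitrogen, 1 sulfur, 1 bromine; one five-membered non-aromatic ring with 1 hetero atom, one six-membered aromatic ring of carbon only) in place of a group of 9 heavy atoms (7 carbon, 1 nitrogen, 1 oxygen; one five-membered aromatic ring with 2 hetero atoms, one six-membered aromatic ring of carbon only), on a sulfur. Within the data shown here, the closest measured step is the one from compound 1 to compound 3, since compound 4 carries the same five-membered non-aromatic ring joined to a thiocarbonyl, with one bromine added. Because that step was a 2.4-fold higher number from compound 1 to compound 3 (0.37 log units; beyond the scatter), a modest weakening of similar size is expected for compound 4, with no basis in the data for the bromine to move the number beyond the scatter. Compound 4 is therefore estimated at 7500 nM, within 3000 nM to 18000 nM, an expected step of a 2.3-fold higher number from compound 1 to compound 4 (0.36 log units; beyond the scatter).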

Compound 4, half-maximal inhibitory concentration: 8060 nM
For compound 4 the middle estimate is 1.1-fold (0.03 log units) below the measured one; low and high end bracket the measured number.
By their numbers in this assay, from the lowest: compound 1; then compounds 2, 3 and 4 (each within the scatter of the next).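

Bromo in place of hydrogen on an aromatic carbon gives a 1.0-fold higher number from compound 3 to compound 4 (0.02 log units; within the scatter) in this assay, so on this read-out the added bromine cannot be told apart from hydrogen. Measured against the 4-ethylpiperazin-1-yl group, the group carrying bromine also gives only a 1.0-fold higher number from compound 2 to compound 4 (0.02 log units; within the scatter), whereas its entry in place of 1,3-benzoxazol-2-yl on the sulfur gives a 2.5-fold higher number from compound 1 to compound 4 (0.39 log units; beyond the scatter). Compounds 2, 3 and 4 thus form one group within the scatter, and among these four compounds only compound 1 stands apart, though no measurement here bears on the reason.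

As far as these compounds go, whether a fluoro or a nitrile on that aromatic carbon would read the same as bromo remains open. Also open, from the compounds shown here alone, is what a carboxylic acid or a longer chain would do in the group on the sulfur.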